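Replacing a ring-bearing hydrazone arm with a chain

The source may report more compounds than this note shows. Statements on the series, on what has been measured and on what is new or still open speak of the compounds shown alone.

Compound 1 `CCOC(=O)C1=C(N/N=C(/C(=O)Br)c2ccc(Br)cc2)Nc2[nH]nc(C)c2C1c1ccc(N(C)C)cc1`: 68500 nM
Compound 2 `CCOC(=O)C1=C(N/N=C(/Cl)c2ccc([N+](=O)[O-])cc2)Nc2[nH]nc(C)c2C1c1ccc(N(C)C)cc1`: 46200 nM

Of the compounds shown here, two built on one shared core have been tested in a functional assay on HeLa cells (Homo sapiens) for inhibition, read by MTT assay, with a stated time of 48 h; a higher number here means a weaker inhibitor, a lower number a stronger inhibitor. Compound 1 gives 68500 nM, and compound 2 gives 46200 nM. Within the data shown here, the only step between them, a 1.5-fold lower number from compound 1 to compound 2 (0.17 log units; within the scatter), swaps one group containing a six-membered aromatic ring of carbon only for another such group on an amine nitrogen, and the two numbers lie within the scatter of each other, so compound 2 stands alongside compound 1 rather than apart from it.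

Compound 3 `CCOC(=O)C1=C(N/N=C(/C(C)=O)C(=O)OCC)Nc2[nH]nc(C)c2C1c1ccc(N(C)C)cc1` has not been measured. It differs from compound 2 by a group of 10 heavy atoms (6 carbon, 1 nitrogen, 3 oxygen; no ring) in place of a group of 12 heavy atoms (7 carbon, 2 nitrogen, 2 oxygen, 1 chlorine; one six-membered aromatic ring of carbon only), on an amine nitrogen. Among the measured compounds shown here, no measured step bears directly on this change, because the single step seen, a 1.5-fold lower number from compound 1 to compound 2 (0.17 log units; within the scatter), kept a ring on that nitrogen and moved the number little. With both measured values weak, compound 3 is expected to remain weak, estimated at 60000 nM, between 20000 nM and 200000 nM. The expected step is a 1.3-fold higher number from compound 2 to compound 3 (0.11 log units; within the scatter).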

Compound 3, half-maximal inhibitory concentration: > 100000 nM
Compound 3 was reported as a limit; the forecaster's own chance of this, stated with the estimate: 25%; middle value at least 1.6-fold (0.22 log units) away from the limit.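

In this assay compound 3 is reported only as a limit, not as a number: the limit of > 100000 nM in this assay, at which 1 of the 3 values shown sits.

Even so, the limit is informative. This is the only change shown that removes the six-membered aromatic ring from the group on the amine nitrogen, and it gives an at least 2.1-fold higher number from compound 2 to compound 3 (0.33 log units; beyond the scatter), so the ring-free group weakens the compound measurably relative to one ring-bearing arm. On these data alone, the other step, an at least 1.4-fold higher number from compound 1 to compound 3 (0.16 log units; that floor lies within the scatter), is less firm, and the true size of both steps stays unknown.

The ring and the rest of the group change together here, so the compounds shown cannot separate the loss of the ring from the effect of what replaces it. As far as these compounds go, whether a chain ending in an amine or a carboxylic acid would fare any differently on this nitrogen also stays open.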